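The source may hold more compounds than are shown below. What is called first, only, known or untested is meant among the compounds shown, and "the series" means these compounds.

Four compounds share one core and are compared in a functional assay on MCF7 cells (Homo sapiens) for antiproliferative activity, read by MTT assay, with a stated time of 72 h; a lower number here means a stronger inhibitor, a higher number a weaker inhibitor. Compound 1 `CC1=CC[C@H]2[C@H](CC[C@]2(C)O)C(C)(C)[C@@H]1CC[C@H]1[C@]2(C)CC[C@H](OC(=O)c3ccc(C)cc3)C(C)(C)O[C@H]2CC[C@@]1(C)O` reaches only a limit, > 50000 nM, so no number is known for it. Compound 2 `CC(=O)O[C@H]1CC[C@]2(C)[C@H](CC[C@@](C)(O)[C@H]2CC[C@@H]2C(C)=CC[C@@H]3C(C)=CC[C@@H]3C2(C)C)OC1(C)C` gives 43500 nM. Compound 3 `CC1=CC[C@H]2[C@H](CC[C@]2(C)O)C(C)(C)[C@@H]1CC[C@H]1[C@]2(C)CC/C(=N/O)C(C)(C)O[C@H]2CC[C@@]1(C)O` gives 46800 nM, within the usual scatter of compound 2. Compound 4 `CC1=CC[C@H]2[C@H](CC[C@]2(C)O)C(C)(C)[C@@H]1CC[C@H]1[C@]2(C)CC[C@H](OC(=O)c3ccc(Cl)c(Cl)c3)C(C)(C)O[C@H]2CC[C@@]1(C)O` has not been measured yet; it differs from compound 1 by 3,4-dichlorophenyl in place of 4-methylphenyl on a carbonyl carbon. For the measured compounds named here, no step between measured compounds is available. Because compound 1 stands at the limit of > 50000 nM in this assay, at which 1 of the 3 values shown sits, and the other two sit close by, the step of an at least 1.1-fold lower number from compound 1 to compound 4 (0.04 log units; that floor lies within the scatter) is expected to stay within the scatter, with no clear direction. Compound 4 is therefore estimated at 45000 nM, in a range from 20000 nM to 100000 nM.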

Compound 4, half-maximal inhibitory concentration: 11900 nM
The estimate for compound 4 lay 3.8-fold (0.58 log units) above the measured number; measured number outside the range, below it.
By their numbers in this assay, from the lowest: compound 4; then compounds 2 and 3 (each within the scatter of the next). At a limit, above all of these: compound 1.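

In this assay, the group on this carbonyl carbon turns out to matter: 3,4-dichlorophenyl in place of 4-methylphenyl gives an at least 4.2-fold lower number from compound 1 to compound 4 (0.62 log units; beyond the scatter). The earlier compounds offered no step at this position, so this is the first change shown to move the number beyond the scatter. From the compounds shown here alone, compound 1 stands at a limit, so the full size of this step stays unknown: the limit of > 50000 nM in this assay, at which 1 of the 4 values shown sits.

Going by these compounds, whether a single chlorine, as in 4-chlorophenyl, would give the same step remains open. So does whether a phenyl carrying an amine or a carboxylic acid here would lower the number further.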